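An Amide Swap at the Carbonyl of Compound 3

A few compounds are considered here, and "the series" means these few. Any claim that something is new, unique, unknown or untested is made for them only; others in the source may bear on it.

In a functional assay on Caco-2 cells (Homo sapiens) for antiproliferative activity, read by MTT assay, with a stated time of 48 h (a higher number here means a weaker inhibitor, a lower number a stronger inhibitor), compound 1 (`CCn1c(C(=O)NCCCN(C)C)ccc1C(CC)(CC)c1ccc(OCCC(O)(CC)CC)c(C)c1`) gives 490 nM as its reading. Compound 2 (`CCOc1ccc(NC(=O)c2ccc(C(CC)(CC)c3ccc(OCCC(O)(CC)CC)c(C)c3)n2CC)cc1`) gives > 50000 nM as a limit of the assay, not a number. Compound 3 (`CCOC(=O)CN(C)C(=O)c1ccc(C(CC)(CC)c2ccc(OCCC(O)(CC)CC)c(C)c2)n1CC`) gives 30300 nM and holds the higher of the two true numbers, with a 62-fold higher number from compound 1 to compound 3 (1.79 log units; beyond the scatter) as a large step. Compound 4 (`CCn1c(C(=O)NC(CO)CCO)ccc1C(CC)(CC)c1ccc(OCCC(O)(CC)CC)c(C)c1`) differs from compound 3 on a carbonyl carbon (a group of 7 heavy atoms (4 carbon, 1 nitrogen, 2 oxygen; no ring) in place of a group of 8 heavy atoms (5 carbon, 1 nitrogen, 2 oxygen; no ring), on a carbonyl carbon) and, like the group leaving, its entering group has no net charge. The step of an at least 100-fold higher number from compound 1 to compound 2 (2.00 log units; beyond the scatter) is also large, while an at least 1.6-fold lower number from compound 2 to compound 3 (0.21 log units; that floor lies within the scatter) has a floor within the scatter. Both large steps remove the 3-(dimethylamino)propyl group, which compound 4 also lacks. Compound 4 is therefore expected to stay close to compound 3 (30300 nM), with no step beyond the scatter expected in this assay for this change. For compound 4 the expected step is a 1.5-fold lower number from compound 3 to compound 4 (0.18 log units; within the scatter) and no more. The estimated value for compound 4 is 20000 nM with an expected range from 6000 nM to 50000 nM at the upper end.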

Compound 4, half-maximal inhibitory concentration: 40200 nM
Beside the measured number, compound 4's estimate is 2.0-fold (0.30 log units) below it, and the stated range covers the measured number.
By their numbers in this assay, from the lowest: compound 1; then compounds 3 and 4 (each within the scatter of the next). At a limit, above all of these: compound 2.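

In this assay the entering group at the carbonyl carbon brings hydrogen-bond donors that the leaving group lacks, and the step is a 1.3-fold higher number from compound 3 to compound 4 (0.12 log units; within the scatter). The 3-hydroxy-1-(hydroxymethyl)propyl group also does not match the 3-(dimethylamino)propyl group on the amide-type nitrogen (an 82-fold higher number from compound 1 to compound 4 (1.91 log units; beyond the scatter)). Among the four compounds, only compound 1 carries that group and only it reads low, with no exception.

Whether the dimethylamino group or its propyl chain sets this reading stays open, and a primary amine, a carboxylic acid or a longer chain ending in dimethylamino is not among the compounds shown. One step gives only a floor: an at least 1.2-fold lower number from compound 2 to compound 4 (0.09 log units; that floor lies within the scatter). Compound 2 stands at a limit of the assay: the limit of > 50000 nM in this assay, at which 1 of the 4 values shown sits.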